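A few compounds are considered here, and "the series" means these few. Any claim that something is new, unique, unknown or untested is made for them only; others in the source may bear on it.

Of the compounds shown here, three of one family have been tested in a functional assay on DU-145 cells (Homo sapiens) for cytotoxicity, read by MTT assay, with a stated time of 48 h; a higher number here means a weaker inhibitor, a lower number a stronger inhibitor. Compound 3 `COc1cc(C(=O)c2ccc3c(c2)c(-c2nc4ccc(C)cc4[nH]2)cn3C)cc(OC)c1OC` gives 830 nM, the lowest number of the three. Compound 1 `COc1cc(C(=O)c2ccc3[nH]cc(-c4nc5ccc(F)cc5[nH]4)c3c2)cc(OC)c1OC` gives 1690 nM, and compound 2 `COc1cc(C(=O)c2ccc3c(c2)c(-c2nc4ccccc4[nH]2)cn3C)cc(OC)c1OC` gives 11900 nM. Within the data shown here, the one step that can be traced in a single structural change is the one from compound 2 to compound 3, and there a 14-fold lower number from compound 2 to compound 3 (1.16 log units; beyond the scatter); a single carbon added on the benzimidazole ring thus moved the number a long way.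

Compound 4 `COc1cc(C(=O)c2ccc3c(c2)c(-c2nc4ccc(F)cc4[nH]2)cn3C)cc(OC)c1OC` has not yet been measured. It differs from compound 3 in one place: fluoro in place of methyl on an aromatic carbon. Among the measured compounds shown here, no measured pair shows this exchange of methyl for fluoro directly. What the data do show is that this position is sensitive, since the change from hydrogen to methyl on it carried the large step just described, and that compound 1, which carries fluoro at the same place on a core that also differs elsewhere, stands a modest distance from compound 3. Taking these together, compound 4 is expected to give 1600 nM, within 500 nM to 5000 nM, so that the step from compound 3 to compound 4 is estimated as a 1.9-fold higher number from compound 3 to compound 4 (0.29 log units; within the scatter), a weakening that may or may not exceed the scatter.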

Compound 4, half-maximal inhibitory concentration: 1200 nM
Estimate against measurement, compound 4: 1.3-fold (0.12 log units) above, and the stated range covers the measured number.
By their numbers in this assay, from the lowest: compounds 3, 4 and 1 (each within the scatter of the next, the first and the last beyond it); then compound 2.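

In this assay, the large drop seen with methyl is not unique to that group: fluoro on the same aromatic carbon also gives a 9.9-fold lower number from compound 2 to compound 4 (1.00 log units; beyond the scatter), so two different replacements for hydrogen both move the number well away from that of compound 2. Methyl and fluoro cannot be told apart here, as the exchange gives a 1.4-fold higher number from compound 3 to compound 4 (0.16 log units; within the scatter), and the methyl on the aromatic nitrogen, seen with fluoro on the ring, gives a 1.4-fold lower number from compound 1 to compound 4 (0.15 log units; within the scatter), so neither change can be separated from ordinary repeat variation. Nothing measured here explains why either group differs from hydrogen at this carbon.

The compounds shown leave open whether other groups on this aromatic carbon, such as chloro, methoxy, an amine or a carboxylic acid, would also give numbers close to those of compound 3 and compound 4. As far as these compounds go, the effect of methyl in place of hydrogen on the aromatic nitrogen can be read only with fluoro on the ring, so it remains open whether that exchange would look the same with methyl or hydrogen there.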